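The source may report more compounds than this note shows. Statements on the series, on what has been measured and on what is new or still open speak of the compounds shown alone.

- compound 1 `N#Cc1cnc(NCc2cnccc2C(F)(F)F)cc1N[C@H]1CC[C@@H](O)CC1`: 33%
- compound 2 `N#Cc1cnc(NCc2cnccc2C(F)(F)F)cc1NC[C@H]1CC[C@@H](O)CC1`: 41%
- compound 3 `N#Cc1cnc(NCc2ccccc2C(F)(F)F)cc1N[C@H]1CC[C@@H](C(N)=O)CC1`: 48%

These three compounds were measured in an ADME assay on S9 fraction from liver (Homo sapiens) for metabolic stability, with a stated time of 1 h; on this read-out lower numbers stand for a less stable compound and higher numbers for a more stable compound. In this assay compound 2 gives 41%, a value within the scatter of both compound 1 at 33% and compound 3 at 48%.

The next compound to be read is compound 4 `CNC(=O)[C@H]1CC[C@@H](Nc2cc(NCc3cnccc3C(F)(F)F)ncc2C#N)CC1`, which differs from compound 2 in one place: 4-(methylcarbamoyl)cyclohexyl in place of (4-hydroxycyclohexyl)methyl on a nitrogen on an aromatic ring. In words, 4-(methylcarbamoyl)cyclohexyl stands in place of (4-hydroxycyclohexyl)methyl on a nitrogen on an aromatic ring.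

Going by the values given here, only one measured step concerns this place. That step, a number 8 percentage points higher from compound 1 to compound 2 (within the scatter), exchanged two hydroxy-bearing groups and did not leave the scatter. Among the compounds with values here, no measured step shows the effect of the 4-(methylcarbamoyl)cyclohexyl group itself. Compound 3, at 48%, also carries a carbonyl-bearing group on its cyclohexyl, but it differs from compound 4 in more than one place, so it offers only loose support.

No step beyond the scatter is therefore expected in this assay. The estimated change is a number 1 percentage points higher from compound 2 to compound 4 (within the scatter). For compound 4 the expected value is 42%, with an estimated range from 26% to 58%.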

Compound 4, percent of the compound remaining: 71%
For compound 4 the middle estimate is 29 percentage points below the measured one, outside the stated range (above it).
By their numbers in this assay, from the lowest: compounds 1, 2 and 3 (each within the scatter of the next, the first and the last beyond it); then compound 4.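

In this assay, the group on the nitrogen on an aromatic ring now proves able to move the number well beyond the scatter, which the earlier exchange of two hydroxy-bearing groups, a number 8 percentage points higher from compound 1 to compound 2 (within the scatter), did not show. 4-(methylcarbamoyl)cyclohexyl in place of (4-hydroxycyclohexyl)methyl gives a number 30 percentage points higher from compound 2 to compound 4 (beyond the scatter), and the cleaner comparison, methylcarbamoyl in place of hydroxy on a saturated ring carbon with nothing else altered, gives a number 38 percentage points higher from compound 1 to compound 4 (beyond the scatter), so among these compounds the largest step comes with the exchange of hydroxy for methylcarbamoyl. The data shown offer no measurement that would explain this rise.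

The compounds shown leave open whether the methylcarbamoyl group is needed as such, or whether a primary carboxamide, a carboxylic acid or an amine on the same saturated ring carbon would give a similar number in this assay. Going by these compounds, it also remains open whether the gain would survive if a longer chain, such as the methylene-extended link of compound 2, were combined with the methylcarbamoyl group.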